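The source may report more compounds than this note shows. Statements on the series, on what has been measured and on what is new or still open speak of the compounds shown alone.

- Compound 1 `COC(=O)N(C)C(C)C#CCN1CCCC1`: > 100 mg/kg
- Compound 2 `CCOC(=O)N(C)CC#CCN1CCCC1`: > 100 mg/kg

Both entries come from a functional assay on the whole organism for antagonist activity, with Mus musculus as the target; a higher number here means that more compound is needed for the effect, a lower number that less compound is needed. For compound 2, the entry > 100 mg/kg is a limit of the assay and not a number. For compound 1, > 100 mg/kg is a limit too, so the pair shows (the limit of > 100 mg/kg in this assay, at which 2 of the 2 values shown sit). Compound 3 `CCOC(=O)N(C)C(C)C#CCN1CCCC1` has methyl in place of hydrogen on a saturated chain carbon bound to an amide-type nitrogen and a triple-bonded carbon. Among the measured compounds shown here, no measured step guides this change, so in this assay the expected result is no shift beyond the scatter, a step that the limit leaves unreadable from compound 2 to compound 3. The estimate for compound 3 is 120 mg/kg, with an expected range of 40 mg/kg to 300 mg/kg.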

Compound 3, dose for half-maximal effect: > 100 mg/kg
Compound 3 gave a limit, no number; the forecaster's own chance of this, stated with the estimate: 70%; the middle value does not contradict the limit.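

Among the compounds shown here, compound 1, compound 2 and compound 3 all give a limit and not a number, so no step between them can be read: the limit of > 100 mg/kg in this assay, at which 3 of the 3 values shown sit. As far as these compounds go, whether methyl in place of hydrogen alters the dose needed in this assay stays open.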